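A few compounds are considered here, and "the series" means these few. Any claim that something is new, unique, unknown or untested is made for them only; others in the source may bear on it.

Measured so far in a functional assay on L1210 cells (Mus musculus), with a stated time of 1 days; on this read-out higher numbers stand for higher potency (the scale is a negative logarithm) and lower numbers for lower potency:

Compound 1, `CCCC1=C(N2CC2)C(=O)C(C(COC(N)=O)OC)=C(N2CC2)C1=O`: 5.01
Compound 2, `CCOC(COC(N)=O)C1=C(N2CC2)C(=O)C(C)=C(N2CC2)C1=O`: 5.53
Compound 3, `CCC1=C(N2CC2)C(=O)C(C(COC(N)=O)OC)=C(N2CC2)C1=O`: 5.62

Among these three, compound 1 stands lowest in this assay. Going by the values given here, compound 2 sits above it, and compound 3 sits higher still; the step of a number 0.61 log units higher from compound 1 to compound 3 (beyond the scatter) is the only single-site change measured here, and it involves hydrogen in place of methyl on a saturated chain carbon.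

The new compound 4, `CCCC1=C(N2CC2)C(=O)C(CCC)=C(N2CC2)C1=O`, differs from compound 1 at a different site: a group of 3 heavy atoms (3 carbon; no ring) in place of a group of 8 heavy atoms (4 carbon, 1 nitrogen, 3 oxygen; no ring), on a double-bonded ring carbon. Among the compounds with values here, none of the measured steps concerns this kind of exchange, so there is no direct guide. What the numbers do show is that all three measured compounds, each carrying the larger group of 8 heavy atoms, lie within a fairly narrow band, with compound 1 at the bottom of it. Within the data shown here, removing that group entirely is a much larger alteration than the one measured from compound 1 to compound 3, so the outcome is uncertain in both direction and size. The step of a number 0.19 log units higher from compound 1 to compound 4 (within the scatter) is the expected change, small and not clearly beyond the scatter. Compound 4 is therefore estimated at 5.2 in this assay, with a range from 4.5 to 5.9.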

Compound 4, logarithm of the reciprocal of the active concentration, log(1/C): 4.32
Compound 4: the middle estimate sits 0.88 log units above what was measured; the whole stated range lies above it.
By their numbers in this assay, from the lowest: compound 4; then compound 1; then compounds 2 and 3 (each within the scatter of the next).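

The side chain on this double-bonded ring carbon, next to the ring atom that bears an aziridin-1-yl group, clearly affects potency: in this assay, propyl in place of the larger group of 8 heavy atoms gives a number 0.69 log units lower from compound 1 to compound 4 (beyond the scatter). Going by these compounds alone, the earlier single-site step concerned only the chain on the other side of the ring, so this is the first sign that this position matters too. The exchange also removes the 1 hydrogen-bond donor and 3 hydrogen-bond acceptors counted on the larger group, since propyl has none, but no measured property explains the loss of potency.

The whole group changes in one step, so the compounds shown do not tell which part of it matters, or whether its size or its hydrogen-bonding atoms count for more. A propyl chain ending in a hydroxyl or an amine, or a longer chain such as butyl, at this position would help separate these possibilities.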